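Compound 4, the mirror image of compound 1

This account rests on a few compounds, and the source may have more. Where it says the series, first, only, none or still open, it means among the compounds named here.

Measured in a physicochemical assay for lipophilicity, measured as octanol-water partition, at pH 7.4; on this read-out higher numbers stand for higher lipophilicity and lower numbers for lower lipophilicity:
- compound 1 `Cc1ccc2[nH]c(C(=O)N[C@H]3CCN(S(=O)(=O)c4ccccc4)C[C@@H]3C(=O)NCCN(C)C)cc2c1`: 2.2
- compound 2 `Cc1ccc2[nH]c(C(=O)N[C@H]3CCN(S(=O)(=O)C4CC4)C[C@@H]3C(=O)NCCN(C)C)cc2c1`: 1
- compound 3 `Cc1ccc2[nH]c(C(=O)N[C@H]3CCN(C(=O)c4cccnc4)C[C@@H]3C(=O)NCCN(C)C)cc2c1`: 0.7

Compound 1 stands highest of these three. The nearest is a number 1.20 log units lower from compound 1 to compound 2 (beyond the scatter), and the furthest is a number 1.50 log units lower from compound 1 to compound 3 (beyond the scatter). The remaining pair shows a number 0.30 log units lower from compound 2 to compound 3 (within the scatter).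

Compound 4 `Cc1ccc2[nH]c(C(=O)N[C@@H]3CCN(S(=O)(=O)c4ccccc4)C[C@H]3C(=O)NCCN(C)C)cc2c1` has not yet been measured. Its relation to compound 1 is the two compounds have the same atoms and bonds and differ only in configuration as drawn: 2 of 2 stereo elements differ (all stereocentres are inverted: mirror images); a stereocentre at a saturated ring carbon is drawn S in compound 1 and R in compound 4; a stereocentre at a saturated ring carbon is drawn S in compound 1 and R in compound 4. Each stereocentre at a saturated ring carbon that is drawn S in compound 1 is drawn R in compound 4.

Among the compounds with values here, none of the measured steps is a change of this kind, since each one replaces a group, so their sizes do not carry over. Here nothing leaves and nothing enters, and mirror images normally behave alike when nothing in the measurement is itself handed. Compound 1, at 2.2, is therefore the best guide.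

In this assay, the expected result is no change at the digits printed from compound 1 to compound 4 (within the scatter), with no step beyond the scatter.

For compound 4 the estimated value is 2.2, with an expected range from 1.9 to 2.5.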

Compound 4, distribution coefficient: 2.3
Compound 4: middle estimate off by 0.10 log units, on the low side; measured number inside the range.
By their numbers in this assay, from the lowest: compounds 3 and 2 (each within the scatter of the next); then compounds 1 and 4 (each within the scatter of the next).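

In this assay, within the data shown here, the earlier steps each replaced a group, whereas this one keeps every atom and bond and inverts both stereocentres at the saturated ring carbons, giving a number 0.10 log units higher from compound 1 to compound 4 (within the scatter). Inverting both centres together therefore leaves this read-out within the scatter, unlike the replacement of phenyl by cyclopropyl on the sulfonyl sulfur, which gives a number 1.20 log units lower from compound 1 to compound 2 (beyond the scatter). The pair isolates handedness as the only variable because of one fact: the fact that compounds 1 and 4 differ only in the configuration as drawn

The compounds shown leave open whether inverting just one of the two stereocentres, which would give a diastereomer and not a mirror image, would also stay within the scatter. They also leave open how a longer alkyl chain in place of phenyl on the sulfonyl sulfur would read in this assay.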